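This account rests on a few compounds, and the source may have more. Where it says the series, first, only, none or still open, it means among the compounds named here.

Measured so far:
- compound 1, `Nc1ncc(-c2cnn(C3CCNCC3)c2)cc1-c1nc2ccc(Nc3cc(C(F)(F)F)cc(C(F)(F)F)c3)cc2o1`: 4200 nM
- compound 2, `Nc1ncc(-c2cnn(C3CCNCC3)c2)cc1-c1nc2ccc(OCc3ccccc3)cc2o1`: 6900 nM

Both values come from an assay on isolated protein for inhibition of G protein-coupled receptor kinase 5 (Homo sapiens), read by TR-FRET, with stated times of 10 min and 1 h; a lower number here means a stronger inhibitor, a higher number a weaker inhibitor. Compound 2 gives the higher of the two numbers in this assay, but its nearest neighbour is compound 1, and the gap between the two lies within the usual scatter of the measurement, so the two compounds cannot be separated on these data. Going by the values given here, no step between measured compounds that differ in only one place is available.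

Compound 3, `Nc1ncc(-c2cnn(C3CCNCC3)c2)cc1-c1nc2ccc(Oc3cc(Cl)ccn3)cc2o1`, is not yet measured. It differs from compound 2 in one place: 4-chloropyridin-2-yl in place of benzyl on an oxygen on an aromatic ring. The shared core of compound 2 is kept, and the change is confined to the group on that oxygen.

Among the compounds with values here, with no matched step to draw on, the expectation for compound 3 is anchored on compound 2 and its value 6900 nM, with no direction assumed. The step from compound 2 to compound 3 is expected to be a 1.3-fold lower number from compound 2 to compound 3 (0.10 log units; within the scatter), that is, none beyond the scatter. For compound 3 in this assay the estimate is 5500 nM, expected to fall between 1500 nM and 20000 nM.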

Compound 3, half-maximal inhibitory concentration: 5700 nM
For compound 3 the middle estimate is 1.0-fold (0.02 log units) below the measured one; the range from low to high includes it.
By their numbers in this assay, from the lowest: compounds 1, 3 and 2 (each within the scatter of the next).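

In this assay, the series now has its first comparison that differs in one place: with 4-chloropyridin-2-yl in place of benzyl on an oxygen on an aromatic ring, the step is a 1.2-fold lower number from compound 2 to compound 3 (0.08 log units; within the scatter), which lies within the scatter. At this position, a ring of carbon only gives way to a ring with one hetero atom, a chlorine and one hydrogen-bond acceptor, at the same count of heavy atoms, and the two compounds cannot be separated on their numbers. No measurement bearing on this result is available to explain it.

Open, going by these compounds, is whether any group on this oxygen gives a number separated from those of compound 2 and compound 3, for instance a plain methyl, a short chain ending in an amine or a chain ending in a carboxylic acid. Also open, on these data alone, is whether a ring carrying the chlorine elsewhere, or a pyridine with no chlorine at all, reads differently from the 4-chloropyridin-2-yl group, since this single step cannot divide its outcome between the ring nitrogen and the chlorine.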